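Trading a Trifluoromethylbenzyl Group for Propargyl

The source may hold more compounds than are shown below. What is called first, only, known or untested is meant among the compounds shown, and "the series" means these compounds.

Compound 1, `CC(C)(C)CC(C)(C)c1ccc(OCC(=O)N2CCN(Cc3ccc(C(F)(F)F)cc3)CC2)cc1`, gives 4740 nM in an assay for inhibition of malate dehydrogenase, cytoplasmic (Homo sapiens), with a stated time of 30 min; a higher number here means a weaker inhibitor, a lower number a stronger inhibitor.
Compound 2, `COC(=O)c1cccc(NC(=O)COc2ccc([N+](=O)[O-])cc2)c1`, reaches only a limit of this assay, reported as > 40000 nM.
Compound 3, `COC(=O)c1cccc(NC(=O)C(C)(C)Oc2ccc(C(C)(C)CC(C)(C)C)cc2)c1`, gives 1400 nM in this assay.

Of the two numbers that this assay has produced, compound 1 carries the higher one and compound 3 the lower, and that gap lies beyond the usual scatter of the measurement. For compound 2 the result is a limit and not a number, as the limit of > 40000 nM in this assay, at which 1 of the 3 values shown sits, records.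

Compound 4, `C#CCN1CCN(C(=O)COc2ccc(C(C)(C)CC(C)(C)C)cc2)CC1`, differs from compound 1 by ethynyl in place of 4-(trifluoromethyl)phenyl on a saturated chain carbon bound to an amine nitrogen in a ring. Among the measured compounds shown here, no measured pair shows this change on its own, so the size of the step can only be judged from the structures. In this assay a step upward is expected, toward a weaker inhibitor, and beyond the scatter. The step from compound 1 to compound 4 is estimated at a 3.2-fold higher number from compound 1 to compound 4 (0.50 log units; beyond the scatter). Compound 4 is therefore expected to give about 15000 nM, most likely between 4000 nM and 60000 nM, with a fair chance that only a limit is reported.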

Compound 4, half-maximal inhibitory concentration: > 40000 nM
Compound 4 gave a limit, no number; the forecaster's own chance of this, stated with the estimate: 25%; middle value at least 2.6-fold (0.42 log units) from the limit.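

The change from 4-(trifluoromethyl)benzyl to propargyl, on the amine nitrogen in the ring, gives an at least 8.4-fold higher number from compound 1 to compound 4 (0.92 log units; beyond the scatter) in this assay. This is the first step shown at this place, and it shows that the group carried there by compound 1 counts for the inhibition of the enzyme: the shared core with propargyl in its place no longer gives a number. How large the loss really is cannot be read, as the result for compound 4 is a limit and not a number: the limit of > 40000 nM in this assay, at which 2 of the 4 values shown sit.

Going by these compounds, what stays open is whether the loss follows the aromatic ring or the trifluoromethyl group, a question that a plain benzyl group at this place would address. On these data alone, it is also open whether a longer chain such as butyl, without any ring, would restore a measurable number.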